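This account rests on a few compounds, and the source may have more. Where it says the series, first, only, none or still open, it means among the compounds named here.

Of the compounds shown here, three that share one core have been tested in an ADME assay on HUVEC cells (Homo sapiens) for cytotoxicity, read by MTT assay, with a stated time of 48 h; on this read-out higher numbers stand for weaker inhibition and lower numbers for stronger inhibition. Compound 1 `Cc1ccc(-c2cn(/N=C/c3cc4cc(C)ccc4nc3Cl)c(N)n2)cc1` carries a 4-methylphenyl group, and in this assay compound 1 gives 18000 nM. Compound 2 `COc1ccc(-c2cn(/N=C/c3cc4cc(C)ccc4nc3Cl)c(N)n2)cc1` carries a 4-methoxyphenyl group instead, and compound 2 gives 12200 nM. Compound 3 `Cc1ccc2nc(Cl)c(/C=N/n3cc(-c4cccc5ccccc45)nc3N)cc2c1` carries naphthalen-1-yl at the same carbon, and compound 3 gives 9580 nM. Compound 3 stands within the scatter of both others: the step of a 1.9-fold lower number from compound 1 to compound 3 (0.27 log units; within the scatter) and the step of a 1.3-fold lower number from compound 2 to compound 3 (0.10 log units; within the scatter) are each too small to count as a real difference, so the three compounds cannot be told apart on these numbers.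

Compound 4 `Cc1ccc2nc(Cl)c(/C=N/n3cc(-c4cccs4)nc3N)cc2c1` has not yet been measured. It differs from compound 3 in one place: thiophen-2-yl in place of naphthalen-1-yl on an aromatic carbon. The measured steps that bear on this change are those that swapped the group at this same carbon, namely a 1.9-fold lower number from compound 1 to compound 3 (0.27 log units; within the scatter) and a 1.3-fold lower number from compound 2 to compound 3 (0.10 log units; within the scatter), and neither moved the number beyond the scatter. Because a 1.3-fold lower number from compound 2 to compound 3 (0.10 log units; within the scatter) stayed within the scatter, no shift beyond the scatter is expected for compound 4 either, which means an expected step of a 1.3-fold higher number from compound 3 to compound 4 (0.10 log units; within the scatter). Compound 4 is therefore estimated to give 12000 nM, with an expected range from 5000 nM to 30000 nM.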

Compound 4, half-maximal inhibitory concentration: 38000 nM
Estimate against measurement, compound 4: 3.2-fold (0.50 log units) below, and the stated range ends below it.
By their numbers in this assay, from the lowest: compounds 3, 2 and 1 (each within the scatter of the next); then compound 4.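

In this assay, this carbon proves sensitive to the group it carries: thiophen-2-yl gives a 4.0-fold higher number from compound 3 to compound 4 (0.60 log units; beyond the scatter), along with a 3.1-fold higher number from compound 2 to compound 4 (0.49 log units; beyond the scatter) and a 2.1-fold higher number from compound 1 to compound 4 (0.32 log units; beyond the scatter), which makes compound 4 the weakest inhibitor of the four. The earlier swaps among 4-methylphenyl, 4-methoxyphenyl and naphthalen-1-yl all stayed within the scatter and could have suggested that the group here hardly matters, but this change shows that the number can move, towards weaker inhibition. No measurement shown here explains this shift, so it remains an observation without a known cause.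

Thiophen-2-yl differs from the other three groups both in its five-membered ring and in its sulfur, and a single compound cannot separate the two, so it remains open whether furan-2-yl, with oxygen in place of sulfur, or an unsubstituted phenyl would follow compound 4 or stay with compounds 1, 2 and 3. Also open, from the compounds shown here alone, is what a non-aromatic group at this carbon, such as cyclohexyl or a morpholine ring, would do to the number.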